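Changing a Benzyl Substituent in an Inactive Ether Series

This account rests on a few compounds, and the source may have more. Where it says the series, first, only, none or still open, it means among the compounds named here.

Compound 1 `COc1ccc(C(OCc2ccccc2)c2cccc3ccccc23)c(OC)c1OC` and compound 2 `COc1ccc(C(OCc2ccc(C)cc2)c2cccc3ccccc23)c(OC)c1OC` share a core in which a benzyl ether hangs from a carbon that also carries two aromatic rings. In a functional assay on THP-1 cells (Homo sapiens) for inhibition, read by sulforhodamine B assay, with a stated time of 48 h (on this read-out lower numbers stand for stronger inhibition and higher numbers for weaker inhibition), compound 1 gives > 20000 nM, which is a limit of the assay rather than a measured number. In this assay compound 2 gives > 20000 nM, again a limit. The step that the two limits leave unreadable from compound 1 to compound 2 therefore cannot be read, as both values sit at the same limit (the limit of > 20000 nM in this assay, at which 2 of the 2 values shown sit).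

Compound 3 `COC(=O)c1ccc(COC(c2ccc(OC)c(OC)c2OC)c2cccc3ccccc23)cc1` differs from compound 2 by methoxycarbonyl in place of methyl on an aromatic carbon. Within the data shown here, no measured step bears on this change in a readable way, since the only step available has no size. With both known compounds at the limit, the expectation for compound 3 is that it also stays there. The step that the limit leaves unreadable from compound 2 to compound 3 is therefore estimated to be none beyond the scatter. Compound 3 is expected to give about 30000 nM in this assay, within a range from 8000 nM to 100000 nM, and most likely to be reported only as a limit.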

Compound 3, half-maximal inhibitory concentration: > 20000 nM
Compound 3: a limit, no number (the forecaster's own chance of this, stated with the estimate: 75%); the middle value is on the limit's open side.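

In this assay compound 3 gives > 20000 nM, which is again a limit and not a measured number. The steps among compound 1, compound 2 and compound 3 cannot be read, as all three values sit at one limit: the limit of > 20000 nM in this assay, at which 3 of the 3 values shown sit.

These compounds leave open how much, if at all, methyl or methoxycarbonyl in place of hydrogen changes inhibition.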